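The source may report more compounds than this note shows. Statements on the series, on what has been measured and on what is new or still open speak of the compounds shown alone.

The series shares the core shown in compound 1 `COc1ccc(OC)c(/C=N/NC(=O)Nc2ccc(Oc3ccnc(-c4nncn4CCN(C)C)c3)c(F)c2)c1`, and the members differ in the aryl group set on a carbon with a double bond to nitrogen. In a functional assay on U-87MG ATCC cells (Homo sapiens) for cytotoxicity, read by MTT assay, with a stated time of 72 h (on this read-out higher numbers stand for weaker inhibition and lower numbers for stronger inhibition), compound 1 gives 6400 nM. Compound 2 `CN(C)CCn1cnnc1-c1cc(Oc2ccc(NC(=O)N/N=C/c3cccc(Br)c3)cc2F)ccn1` carries 3-bromophenyl there, and in this assay compound 2 gives 830 nM, so that a 7.7-fold lower number from compound 1 to compound 2 (0.89 log units; beyond the scatter). Compound 3 `CN(C)CCn1cnnc1-c1cc(Oc2ccc(NC(=O)N/N=C/c3ccc(O)c(F)c3)cc2F)ccn1` carries 3-fluoro-4-hydroxyphenyl. In this assay compound 3 reaches only > 100000 nM, which is a limit of the assay and not a number. Compound 3 thus sits at the limit of > 100000 nM in this assay, at which 1 of the 3 values shown sits, and it is the weakest of the three, since an at least 15-fold higher number from compound 1 to compound 3 (1.19 log units; beyond the scatter) and an at least 120-fold higher number from compound 2 to compound 3 (2.08 log units; beyond the scatter). Compound 4 `CN(C)CCn1cnnc1-c1cc(Oc2ccc(NC(=O)N/N=C/c3c(Cl)cccc3Cl)cc2F)ccn1` has not yet been measured in this assay. It differs from compound 3 by 2,6-dichlorophenyl in place of 3-fluoro-4-hydroxyphenyl on a carbon with a double bond to nitrogen. The step that bears most directly on this change is the one from the 3-bromophenyl of compound 2 to the hydroxylated aryl of compound 3, a large rise; putting a halogenated aryl back in place of the hydroxylated one points to a step of comparable size in the opposite direction. Compound 2 shows where such an aryl has landed before, at 830 nM. Compound 4 is therefore expected to show an at least 50-fold lower number from compound 3 to compound 4 (1.69 log units; beyond the scatter) in this assay. The estimate for compound 4 is 2000 nM, within a range from 400 nM to 10000 nM.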

Compound 4, half-maximal inhibitory concentration: > 100000 nM
Compound 4: only a limit was reported (the forecaster's own chance of this, stated with the estimate: 10%); at least 50-fold (1.69 log units) between middle value and limit.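

In this assay, a halogenated aryl on a carbon with a double bond to nitrogen does not by itself carry the activity seen for compound 2: an at least 120-fold higher number from compound 2 to compound 4 (2.08 log units; beyond the scatter), and an at least 15-fold higher number from compound 1 to compound 4 (1.19 log units; beyond the scatter). The reading for compound 4 is a limit and not a number, and the step from compound 3 cannot be read, as both compounds stand at limits, so 2,6-dichlorophenyl and 3-fluoro-4-hydroxyphenyl cannot be ranked against each other. A hydroxyl on the aryl is thus not needed for a compound of this series to reach that limit, as 2,6-dichlorophenyl has none and the count of compounds there has grown: the limit of > 100000 nM in this assay, at which 2 of the 4 values shown sit.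

The compounds shown leave open whether the gap from 3-bromophenyl to 2,6-dichlorophenyl follows from the kind of halogen, the number of halogens or where they sit, as these two groups differ in all three at once. A 3-chlorophenyl group on the same carbon would separate the kind of halogen from the other two, and a 2-chlorophenyl group would bear on where a single halogen sits.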